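Aryl exchange on the shared core

This account rests on a few compounds, and the source may have more. Where it says the series, first, only, none or still open, it means among the compounds named here.

In a functional assay on A2780 cells (Homo sapiens) for antiproliferative activity, read by MTT assay, with a stated time of 48 h (on this read-out lower numbers stand for stronger inhibition of growth and higher numbers for weaker inhibition of growth), compound 1 `CCOc1cccc(C2=NN(C(=O)OC)C(c3cc(OC)c(OC)c(OC)c3)C2)c1` gives 760 nM, compound 2 `COC(=O)N1N=C(c2cccc(Cl)c2)CC1c1cc(OC)c(OC)c(OC)c1` gives 1540 nM and compound 3 `COC(=O)N1N=C(c2ccc(O)cc2)CC1c1cc(OC)c(OC)c(OC)c1` gives 2520 nM. Compound 3 lies within the scatter of compound 2 and stands clear of compound 1 only. Compound 4 `COC(=O)N1N=C(c2ccc(OC)c(OC)c2)CC1c1cc(OC)c(OC)c(OC)c1` carries 3,4-dimethoxyphenyl in place of 4-hydroxyphenyl on a carbon with a double bond to nitrogen. Two measured aryl exchanges bear on this: the modest 3.3-fold higher number from compound 1 to compound 3 (0.52 log units; beyond the scatter), and a 1.6-fold higher number from compound 2 to compound 3 (0.21 log units; within the scatter), which stays within the scatter. Going by the values given here, the nearest precedent is the 3-ethoxyphenyl of compound 1, so a modest step to a lower number is expected, no larger than the first of these. The expected change is a 2.5-fold lower number from compound 3 to compound 4 (0.40 log units; beyond the scatter). For compound 4 the estimated value is 1000 nM, with an expected range of 350 nM to 2800 nM.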

Compound 4, concentration for 50% growth inhibition: 11400 nM
For compound 4 the middle estimate is 11-fold (1.06 log units) below the measured one, outside the stated range (above it).
By their numbers in this assay, from the lowest: compound 1; then compounds 2 and 3 (each within the scatter of the next); then compound 4.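

In this assay the 3,4-dimethoxyphenyl group gives a 4.5-fold higher number from compound 3 to compound 4 (0.66 log units; beyond the scatter) and a 7.4-fold higher number from compound 2 to compound 4 (0.87 log units; beyond the scatter) and also a 15-fold higher number from compound 1 to compound 4 (1.18 log units; beyond the scatter) at this position. An oxygen-bearing aryl group therefore does not by itself keep the number low here, since the 3-ethoxyphenyl of compound 1 and the 3,4-dimethoxyphenyl of compound 4 stand furthest apart in the series. Nothing at hand explains this rise.

Going by these compounds alone, open is where 4-methoxyphenyl, 3-methoxyphenyl or an aminophenyl group would fall on this read-out, and so whether one methoxy group alone or only the pair goes with the higher number.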